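Hydroxy to nitro on compound 3, read for cytotoxicity

The compounds below may be only part of what the source reports. "The series", "measured", "known", "first", "only" and "open" are said of these compounds alone.

In an ADME assay on Vero cells (Chlorocebus sabaeus) for cytotoxicity (on this read-out higher numbers stand for lower toxicity in this test and lower numbers for higher toxicity in this test), compound 3 (`Oc1ccc(-c2nc3cc(C(F)(F)F)ccc3[nH]2)cc1`) gives > 100000 nM as a limit of the assay and not as a number. Compound 1 (`O=[N+]([O-])c1ccccc1-c1nc2ccccc2[nH]1`) gives > 100000 nM as a limit as well. Compound 2 (`O=[N+]([O-])c1ccc(-c2nc3ccccc3[nH]2)c([N+](=O)[O-])c1`) likewise gives > 100000 nM as a limit. For the measured compounds named here, the series so far therefore offers only the limit of > 100000 nM in this assay, at which 3 of the 3 values shown sit, and no measured number.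

Compound 4 (`O=[N+]([O-])c1ccc(-c2nc3cc(C(F)(F)F)ccc3[nH]2)cc1`) carries nitro in place of hydroxy on an aromatic carbon, para to a large group: nitro in place of hydroxy on an aromatic carbon is the whole change. Going by the values given here, the one measured step that brings in nitro is a step that the two limits leave unreadable from compound 1 to compound 2 and there nitro replaces hydrogen rather than hydroxy, so it gives only weak guidance here. On that thin basis, the expected change is an at least 1.4-fold lower number from compound 3 to compound 4 (0.15 log units; that floor lies within the scatter) and it would most likely be small, toward lower numbers if it shows at all. A reading at the limit again is also expected to be quite possible. Compound 4 is estimated at 70000 nM within an expected range from 20000 nM to 100000 nM in this assay for now.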

Compound 4, half-maximal cytotoxic concentration: 45000 nM
For compound 4 the middle estimate is 1.6-fold (0.19 log units) above the measured one; measured number inside the range.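

In this assay, nitro in place of hydroxy on an aromatic carbon, para to a large group, gives an at least 2.2-fold lower number from compound 3 to compound 4 (0.34 log units; beyond the scatter), which shows that this position can move the read-out. Compound 4 is the only compound shown with a measured number and not a limit: the limit of > 100000 nM in this assay, at which 3 of the 4 values shown sit. For the compounds shown here, the earlier step, from one nitro compound to the other, cannot be read, which leaves this as the first readable step; compound 3 is itself a limit, and the step therefore gives only a minimum size.

As far as these compounds go, whether the lower number comes with the nitro group or with the loss of hydroxy remains open, as does the effect of an amine or a carboxylic acid at this position. The compounds shown also offer no partner for compound 4 that differs only at the trifluoromethyl group, leaving the part played by that group unresolved.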